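Dithiocarbamate series: swapping the piperazine substituent in compound 1

The source may report more compounds than this note shows. Statements on the series, on what has been measured and on what is new or still open speak of the compounds shown alone.

Compound 1 `Nc1ccccc1NC(=O)c1ccc(CSC(=S)N2CCN(Cc3ccccn3)CC2)cc1` sits at the bottom of the three numbers in a functional assay on A-375 cells (Homo sapiens) for antiproliferative activity, read by CCK-8 assay, with a stated time of 72 h, tested at 8 uM; a lower number here means a weaker effect, a higher number a stronger effect of the compound at the concentration tested: compound 1 gives 82.4%, compound 2 `CC1CCCCN1C(=S)SCc1ccc(C(=O)Nc2ccccc2N)cc1` gives 85.2% and compound 3 `CCN(Cc1ccncc1)C(=S)SCc1ccc(C(=O)Nc2ccccc2N)cc1` gives 86.2%, all three within the scatter of one another. Among the measured compounds shown here, the only measured step, a number 1 percentage points higher from compound 2 to compound 3 (within the scatter), changes the group on the thiocarbonyl nitrogen and moves nothing beyond the scatter. Compound 4 `Nc1ccccc1NC(=O)c1ccc(CSC(=S)N2CCN(c3ccccc3F)CC2)cc1` is compound 1 with 2-fluorophenyl in place of (pyridin-2-yl)methyl on an amine nitrogen in a ring. For the measured compounds named here, the change again sits at the far end of the dithiocarbamate, where the one measured step was flat, so no step beyond the scatter is expected in this assay; the expected step is a number 0.6 percentage points higher from compound 1 to compound 4 (within the scatter). Compound 4 is therefore estimated at 83%, with a range from 72% to 92%.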

Compound 4, a percentage reported as inhibition, at one concentration (the size of the read-out at that concentration, not a potency): 79.5%
Estimate against measurement, compound 4: 3.5 percentage points above; measured number inside the range.
By their numbers in this assay, from the lowest: compounds 4, 1, 2 and 3 (each within the scatter of the next).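

In this assay, among the compounds shown here, 2-fluorophenyl in place of (pyridin-2-yl)methyl on the amine nitrogen in the ring gives a number 2.9 percentage points lower from compound 1 to compound 4 (within the scatter) and is the first step read at this position. The read-out stays within the scatter when a ring of carbon only replaces the ring with a hetero atom, and the group's hydrogen-bond acceptor is lost. No available data bear on the reason for this result.

On these data alone, whether a carboxylic acid or a primary amine on this ring nitrogen would move the read-out beyond the scatter remains open. So does whether these compounds would separate at a lower concentration.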